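A few compounds are considered here, and "the series" means these few. Any claim that something is new, unique, unknown or untested is made for them only; others in the source may bear on it.

In a functional assay on MGC-803 cells (Homo sapiens) for inhibition, read by CCK-8 assay, with a stated time of 48 h (a lower number here means a stronger inhibitor, a higher number a weaker inhibitor), compound 2 `COc1ccc(CN(C(=O)CSC(=S)N2CCN(C(=O)OC(C)(C)C)CC2)c2cc(OC)c(OC)c(OC)c2)cc1` gives 310 nM, the lowest of the three measured numbers. Compound 1 `COc1ccc(CN(C(=O)CSC(=S)N2CCN(C)CC2)c2cc(OC)c(OC)c(OC)c2)cc1` gives 1280 nM, and compound 3 `COc1ccc(CN(C(=O)CSC(=S)N2CCN(Cc3ccc(C(C)(C)C)cc3)CC2)c2cc(OC)c(OC)c(OC)c2)cc1` gives 5390 nM. Compound 4 `COc1ccc(CN(C(=O)CSC(=S)N2CCN(C(=O)OC(C)(C)C)CC2)c2ccc(Cl)cc2)cc1` has 4-chlorophenyl in place of 3,4,5-trimethoxyphenyl on an amide-type nitrogen. Within the data shown here, no measured step touches this place, since compounds 1, 2 and 3 all keep 3,4,5-trimethoxyphenyl. The steps elsewhere, a 4.1-fold lower number from compound 1 to compound 2 (0.62 log units; beyond the scatter) and a 17-fold higher number from compound 2 to compound 3 (1.24 log units; beyond the scatter), bear only indirectly, showing that single changes in this series range from modest to large in this assay. The direction is unproven, but a modest rise is the working expectation, with an estimated step of a 3.9-fold higher number from compound 2 to compound 4 (0.59 log units; beyond the scatter). The expected value for compound 4 is 1200 nM, within an estimated range of 250 nM to 6000 nM.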

Compound 4, half-maximal inhibitory concentration: > 20000 nM
Compound 4: a limit, no number; the forecaster's own chance of this, stated with the estimate: 3%; middle value at least 16-fold (1.22 log units) from the limit.
By their numbers in this assay, from the lowest: compound 2; then compound 1; then compound 3. At a limit, above all of these: compound 4.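

Placing 4-chlorophenyl in place of 3,4,5-trimethoxyphenyl on the amide-type nitrogen gives an at least 64-fold higher number from compound 2 to compound 4 (1.80 log units; beyond the scatter), the first evidence that this position, unchanged across compounds 1, 2 and 3, can strongly affect the read-out. Compound 4 gives a limit, not a number: the limit of > 20000 nM in this assay, at which 1 of the 4 values shown sits. Going by these compounds, the full size of the step therefore remains unknown.

Still open, on these data alone, is whether the step follows from losing the methoxy groups or from introducing chlorine; a 4-methoxyphenyl or 3,5-dimethoxyphenyl group on this nitrogen would separate the two.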